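The source may report more compounds than this note shows. Statements on the series, on what has been measured and on what is new or still open speak of the compounds shown alone.

Working notes on the series. Among the measured compounds shown here, the three compounds measured so far share one core and differ only in the aryl group attached to the amide carbonyl carbon. In a functional assay on MCF7 cells (Homo sapiens) for antiproliferative activity, read by CCK-8 assay, with a stated time of 72 h (a lower number here means a stronger inhibitor, a higher number a weaker inhibitor), compound 1 `COc1ccc(C(=O)Nc2ccc(C(=O)/C=C/c3nc(C)c(C)nc3C)cc2)cc1OC` gives 1660 nM. In this assay compound 2 `Cc1ccc(C(=O)Nc2ccc(C(=O)/C=C/c3nc(C)c(C)nc3C)cc2)cc1` gives 1180 nM, and in this assay compound 3 `Cc1nc(C)c(/C=C/C(=O)c2ccc(NC(=O)c3ccc(F)cc3F)cc2)nc1C` gives 1610 nM. Compound 3 thus stands second highest of the three numbers, with compound 1 nearest and compound 2 furthest; all three values sit within the scatter of one another, as the steps of a 1.4-fold lower number from compound 1 to compound 2 (0.15 log units; within the scatter), a 1.0-fold lower number from compound 1 to compound 3 (0.01 log units; within the scatter) and a 1.4-fold higher number from compound 2 to compound 3 (0.13 log units; within the scatter) show.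

Compound 4 `COc1cc(OC)cc(C(=O)Nc2ccc(C(=O)/C=C/c3nc(C)c(C)nc3C)cc2)c1` is not yet measured. The change from compound 3 is 3,5-dimethoxyphenyl in place of 2,4-difluorophenyl on a carbonyl carbon. Every step seen so far is a swap of exactly this aryl group on the carbonyl carbon, and none of the three left the scatter, whether the group carried methyl, fluorine or methoxy substituents. On that basis no step beyond the scatter is expected in this assay for this swap either, in neither direction. Compound 4 is therefore expected to give about 1500 nM in this assay, with a range from 700 nM to 3200 nM. The estimated step of a 1.1-fold lower number from compound 3 to compound 4 (0.03 log units; within the scatter) is expected to stay within the scatter.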

Compound 4, half-maximal inhibitory concentration: 6270 nM
The estimate for compound 4 lay 4.2-fold (0.62 log units) below the measured number; measured number above the stated range.
By their numbers in this assay, from the lowest: compounds 2, 3 and 1 (each within the scatter of the next); then compound 4.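

In this assay, among the compounds shown here, this position on the carbonyl carbon no longer looks indifferent to the aryl group: 3,5-dimethoxyphenyl gives the first steps beyond the scatter, namely a 3.9-fold higher number from compound 3 to compound 4 (0.59 log units; beyond the scatter) and a 5.3-fold higher number from compound 2 to compound 4 (0.73 log units; beyond the scatter) and a 3.8-fold higher number from compound 1 to compound 4 (0.58 log units; beyond the scatter) in turn. The last of these is the most telling, since 3,4-dimethoxyphenyl and 3,5-dimethoxyphenyl carry the same two methoxy groups and differ only in where these sit on the ring, so the mere presence of two methoxy groups does not go with the higher number, and compound 1 stands against any such reading. No measurement at hand explains why this swap moves the number while the earlier swaps did not.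

From the compounds shown here alone, it remains open whether the higher number follows the methoxy groups or the substitution pattern, which a 3,5-difluorophenyl or 3,5-dimethylphenyl group at this position would help to separate. A single 3-methoxyphenyl group, or an unsubstituted phenyl or pyridyl ring, would also show whether any group here can give a number clearly lower than those of compounds 1, 2 and 3.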